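A Second Trifluoromethoxy Exchange on a Series at Its Limit

The source may report more compounds than this note shows. Statements on the series, on what has been measured and on what is new or still open speak of the compounds shown alone.

In an ADME assay on BJ cells (Homo sapiens) for cytotoxicity, read by luminescence, with a stated time of 72 h (on this read-out lower numbers stand for an effect already at smaller amounts and higher numbers for an effect only at larger amounts of compound), compound 1 (`CCOC(=O)c1c(-c2cccc(OC)c2)[nH]c2cc(OC)ccc2c1=O`) gives > 21500 nM as a limit of the assay, not a number. Compound 2 (`CCOC(=O)c1c(-c2cccc(OC(F)(F)F)c2)[nH]c2cc(OC)ccc2c1=O`) gives > 21500 nM, which is again a limit. Compound 3 (`CCOC(=O)c1c(-c2cccc(OC)c2)[nH]c2cc(OC(F)(F)F)ccc2c1=O`) stands at > 21500 nM, also only a limit. The series thus offers the limit of > 21500 nM in this assay, at which 3 of the 3 values shown sit, and no measured number at all.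

The next compound, compound 4 (`CCOC(=O)c1c(-c2cccc(OC(F)(F)F)c2)[nH]c2cc(OC(F)(F)F)ccc2c1=O`), differs from compound 3 by one exchange: trifluoromethyl in place of methyl on an oxygen on an aromatic ring, that is, methoxy to trifluoromethoxy. Two measured steps make this same kind of exchange. One is a step that the two limits leave unreadable from compound 1 to compound 2 and the other is a step that the two limits leave unreadable from compound 1 to compound 3 in the same assay. Neither gives a size, so they offer no sign of a shift in either direction, and they give no proof that none occurs. Taking a step that the two limits leave unreadable from compound 1 to compound 2 as the closest precedent, no step beyond the scatter is expected, and the estimate is a step that the limit leaves unreadable from compound 3 to compound 4 in this assay. Most likely the assay will again report only a limit. For compound 4 the expected value is 25000 nM, with an estimated range from 12000 nM to 45000 nM as the outcome.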

Compound 4, half-maximal effective concentration: > 21500 nM
Compound 4 gave a limit, no number; the forecaster's own chance of this, stated with the estimate: 85%; the middle value is on the limit's open side.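

In this assay compound 4 gives > 21500 nM, again a limit of the assay and not a number, so its steps from compound 2 and from compound 3 cannot be read. The series now stands as follows: the limit of > 21500 nM in this assay, at which 4 of the 4 values shown sit.

The compounds shown leave open whether methoxy to trifluoromethoxy shifts this read-out at all, in either direction.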